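Chloro for ethyl on the core of compound 2

The compounds below may be only part of what the source reports. "The series", "measured", "known", "first", "only" and "open" are said of these compounds alone.

Measured compounds:
compound 1 `C[C@@H](Oc1cc2onc(CCC(=O)O)c2cc1Cl)c1ccc(Cl)cn1` 3.98 nM
compound 2 `CCc1cc2oc(=O)n(CCC(=O)O)c2cc1Cl` 316 nM
compound 3 `C[C@@H](Oc1cc2oc(=O)n(CCC(=O)O)c2cc1Cl)c1cccnn1` 631 nM

Of the compounds shown here, three have been measured in an assay on HEK293 cells for inhibition of kynurenine 3-monooxygenase (Homo sapiens), read by LC-MS, with a stated time of 20 h; on this read-out higher numbers stand for weaker inhibition and lower numbers for stronger inhibition. Compound 1 gives 3.98 nM in this assay, compound 2 gives 316 nM and compound 3 gives 631 nM. Among these three numbers compound 2 holds the second highest. Its closest neighbour is compound 3, whose value lies within the scatter of that of compound 2, so the two cannot be ordered. The value of compound 1 lies far below that of compound 2, well beyond the scatter.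

The next compound, compound 4 `O=C(O)CCn1c(=O)oc2cc(Cl)c(Cl)cc21`, has not yet been measured in this assay. It differs from compound 2 in a single place: chloro in place of ethyl on an aromatic carbon. The fused core, the chloro group already present on it and the carboxylic acid chain on the other ring are unchanged. For the measured compounds named here, none of the measured pairs shows a comparable exchange, so no measured step tells how this assay responds to it. Going by the values given here, with no comparable step in hand, the expected step from compound 2 to compound 4 is a small one, a 1.6-fold higher number from compound 2 to compound 4 (0.20 log units; within the scatter), which may fall within the scatter. The estimate for compound 4 in this assay is 500 nM, with a range from 150 nM to 1600 nM.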

Compound 4, half-maximal inhibitory concentration: 2000 nM
For compound 4 the middle estimate is 4.0-fold (0.60 log units) below the measured one; the whole stated range lies below it.
By their numbers in this assay, from the lowest: compound 1; then compounds 2 and 3 (each within the scatter of the next); then compound 4.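

In this assay, for the compounds shown here, the exchange of ethyl for chloro gives the first step between compounds differing in one place, a 6.3-fold higher number from compound 2 to compound 4 (0.80 log units; beyond the scatter), and so shows that this position responds to what it carries. With the fused core, the existing chloro group and the carboxylic acid chain unchanged, ethyl on this aromatic carbon, ortho to a chloro group, gives stronger inhibition than chloro, even though neither group counts any hydrogen-bond donors, hydrogen-bond acceptors or net charge. Nothing available accounts for this step, so the data record its direction and size but not its origin.

The compounds shown compare only ethyl and chloro at this position, so a single step cannot show whether the number would keep falling along a series running from methyl through ethyl to a longer chain such as propyl. Going by these compounds, it also remains open how a methoxy group, an amine or a nitrile on this same carbon would compare with ethyl and chloro, and whether the step would keep its size on a different core.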